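Series notes: from compound 3 to compound 4

The source may report more compounds than this note shows. Statements on the series, on what has been measured and on what is new or still open speak of the compounds shown alone.

Compound 3 `COc1ccccc1-n1nncc1CN1C(=O)C2(C(C#N)=C(N)Oc3c2c2nc4ccccc4nc2c2ccccc32)c2ccccc21` gives > 50000 nM in a functional assay on MCF7 cells (Homo sapiens) for antiproliferative activity, read by MTT assay, with a stated time of 48 h; on this read-out higher numbers stand for weaker inhibition and lower numbers for stronger inhibition; this is a limit of the assay and not a number. Compound 2 `N#CC1=C(N)Oc2c(c3nc4ccccc4nc3c3ccccc23)C12C(=O)N(Cc1cnnn1-c1ccccc1Br)c1ccccc12` likewise gives > 50000 nM in this assay, again a limit. Compound 1 `N#CC1=C(N)Oc2c(c3nc4ccccc4nc3c3ccccc23)C12C(=O)N(Cc1cnnn1-c1cccc(Cl)c1)c1ccccc12` gives 43600 nM in this assay. The step of an at least 1.1-fold higher number from compound 1 to compound 3 (0.05 log units; that floor lies within the scatter) and the step of an at least 1.1-fold higher number from compound 1 to compound 2 (0.05 log units; that floor lies within the scatter) are therefore read only as floors, and the step that the two limits leave unreadable from compound 2 to compound 3 cannot be read at all. The whole picture is dominated by the limit of > 50000 nM in this assay, at which 2 of the 3 values shown sit. Compound 4 `CCOc1ccccc1-n1nncc1CN1C(=O)C2(C(C#N)=C(N)Oc3c2c2nc4ccccc4nc2c2ccccc32)c2ccccc21` differs from compound 3 by methyl in place of hydrogen on a saturated chain carbon bound to an oxygen on an aromatic ring, the methoxy group becoming an ethoxy group on the 2-methoxyphenyl. Among the measured compounds shown here, no measured step changes the methoxy group itself, so none bears directly on this change; the steps that touch the same aryl group are floors within the scatter. Compound 3 stands at the limit. For compound 4 the estimate is 60000 nM, with a range of 25000 nM to 150000 nM. The step that the limit leaves unreadable from compound 3 to compound 4 is expected to stay within the scatter, most likely returning another limit.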

Compound 4, half-maximal inhibitory concentration: > 50000 nM
Compound 4: a limit, no number; the forecaster's own chance of this, stated with the estimate: 65%; the middle value lies beyond the limit too.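

The change from 2-methoxyphenyl to 2-ethoxyphenyl is the first one shown on the methoxy group itself, and in this assay the added methyl does not bring compound 4 to a measurable number. Among the compounds shown here, the steps to compound 4 from compound 2 and from compound 3 cannot be read, as both ends are limits, and the one readable step, an at least 1.1-fold higher number from compound 1 to compound 4 (0.05 log units; that floor lies within the scatter), gives only a floor. The series therefore stays where it was, now with one more compound at the same limit: the limit of > 50000 nM in this assay, at which 3 of the 4 values shown sit.

On these data alone, compound 1 alone carries a number, so the size of any effect of a change on this aryl group remains open. Also open, as far as these compounds go, is whether a longer chain in place of ethoxy, or an amine or a carboxylic acid on that ring, would give a value below the limit.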